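A few compounds are considered here, and "the series" means these few. Any claim that something is new, unique, unknown or untested is made for them only; others in the source may bear on it.

Going by the values given here, compound 2 `CC1(C)[C@H]2CC[C@]1(C)N(Cc1cn(-c3ccc(Cl)cc3)nn1)C(=O)C2` gives 160 nM in a functional assay on LoVo cells (Homo sapiens) for inhibition, read by MTT assay, with a stated time of 24 h (a higher number here means a weaker inhibitor, a lower number a stronger inhibitor), the highest of the three numbers so far, though its gap to compound 3 lies within the scatter and only that to compound 1 lies beyond it. Compound 1 `CC1(C)[C@H]2CC[C@]1(C)N(Cc1cn(-c3cccc(Cl)c3)nn1)C(=O)C2` gives 70 nM and compound 3 `Cc1ccccc1-n1cc(CN2C(=O)C[C@@H]3CC[C@@]2(C)C3(C)C)nn1` gives 80 nM; the step was a 2.3-fold higher number from compound 1 to compound 2 (0.36 log units; beyond the scatter), and then a 2.0-fold lower number from compound 2 to compound 3 (0.30 log units; within the scatter). Compound 4 `COc1ccc(-n2cc(CN3C(=O)C[C@@H]4CC[C@@]3(C)C4(C)C)nn2)cc1` differs from compound 2 by methoxy in place of chloro on an aromatic carbon. Among the compounds with values here, no measured step swaps chloro for methoxy; the steps at hand all concern the aryl ring and are small, a 1.1-fold higher number from compound 1 to compound 3 (0.06 log units; within the scatter) among them, so in this assay a step within the scatter, in either direction, is expected. The expected step is a 1.1-fold lower number from compound 2 to compound 4 (0.03 log units; within the scatter). Compound 4 is therefore expected to give 150 nM, within a range of 60 nM to 400 nM.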

Compound 4, half-maximal inhibitory concentration: 70 nM
Estimate against measurement, compound 4: 2.1-fold (0.33 log units) above, within the range that was stated.
By their numbers in this assay, from the lowest: compounds 1, 4, 3 and 2 (each within the scatter of the next, the first and the last beyond it).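

On the aromatic carbon para to a large group, methoxy in place of chloro gives a 2.3-fold lower number from compound 2 to compound 4 (0.36 log units; beyond the scatter) and is the first change shown that alters only the substituent at this place. With a 1.1-fold lower number from compound 3 to compound 4 (0.06 log units; within the scatter) and no change at the digits printed from compound 1 to compound 4 (within the scatter) as well, the 4-methoxyphenyl group sits level with the 2-methylphenyl and 3-chlorophenyl groups, leaving the 4-chlorophenyl group of compound 2 apart from compounds 1 and 4 but not from compound 3. Nothing measured here accounts for this step. On these data alone, whether an amine, a carboxylic acid or a longer chain on this carbon would match methoxy or chloro stays open.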